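Exchanging the group on the aromatic oxygen of compound 2

The compounds below may be only part of what the source reports. "The series", "measured", "known", "first", "only" and "open" are said of these compounds alone.

Going by the values given here, in an ADME assay on microsomes from liver (Rattus norvegicus) for metabolic stability, read by LC-MS, tested at 1 uM (on this read-out higher numbers stand for fast clearance and lower numbers for slow clearance), compound 1 (`NC(=O)C1CCN(Cc2ccc([C@H]3CC[C@]4(CC3)OOC3(O4)C4CC5CC(C4)CC3C5)cc2)CC1`) gives 25 mL.min-1.g-1 and compound 2 (`c1cc([C@H]2CC[C@]3(CC2)OOC2(O3)C3CC4CC(C3)CC2C4)ccc1OC1CCNCC1`) gives 21 mL.min-1.g-1, so compound 2 stands within the scatter of the only other measured compound. Compound 3 (`N[C@H]1CC[C@@H](Oc2ccc([C@H]3CC[C@]4(CC3)OOC3(O4)C4CC5CC(C4)CC3C5)cc2)CC1`) shares the core of compound 2 and differs in one place: 4-aminocyclohexyl in place of piperidin-4-yl on an oxygen on an aromatic ring. Put simply, 4-aminocyclohexyl stands in place of piperidin-4-yl on an oxygen on an aromatic ring. Among the compounds with values here, no measured step covers this exchange. Within the data shown here, the only step available, a 1.2-fold lower number from compound 1 to compound 2 (0.08 log units; within the scatter), is a different exchange, (piperidin-4-yl)oxy in place of (4-carbamoylpiperidin-1-yl)methyl on an aromatic carbon, and it stayed within the scatter. On that limited evidence, no step beyond the scatter is expected in this assay, and the expected change is a 1.0-fold higher number from compound 2 to compound 3 (0.02 log units; within the scatter). The estimate for compound 3 is 22 mL.min-1.g-1, with an expected range of 11 mL.min-1.g-1 to 44 mL.min-1.g-1.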

Compound 3, intrinsic clearance in microsomes: < 7 mL.min-1.g-1
Compound 3: no number, only a limit; the forecaster's own chance of this, stated with the estimate: 3%; middle value at least 3.1-fold (0.49 log units) away from the limit.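

In this assay, going by these compounds alone, the group on the oxygen on the aromatic ring turns out to matter: replacing piperidin-4-yl with 4-aminocyclohexyl gives an at least 3.0-fold lower number from compound 2 to compound 3 (0.47 log units; beyond the scatter), whereas the one earlier step, a different exchange, stayed within the scatter. The comparison with the first compound reads the same way, with an at least 3.5-fold lower number from compound 1 to compound 3 (0.55 log units; beyond the scatter). The value of compound 3 is a limit of the assay and not a number, so both steps fix only the smallest size the change can have: the limit of < 7 mL.min-1.g-1 in this assay, at which 1 of the 3 values shown sits.

From the compounds shown here alone, how far compound 3 lies past that limit remains open, as does the part played by the two defined stereocentres of 4-aminocyclohexyl. Going by these compounds, it is also open whether a plain cyclohexyl or a 4-hydroxycyclohexyl on the same oxygen, with no amine, would read like compound 3 or like compound 2.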